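The compounds below may be only part of what the source reports. "The series", "measured", "known", "first", "only" and "open" are said of these compounds alone.

Measured so far:
compound 1 `C=CC1=C(C(=O)O)C(c2ccc(OC)cc2)OC1` — > 100000 nM
compound 2 `C=CC1=C(C(=O)NCc2ccccc2F)C(c2ccc(F)cc2)OC1` — > 100000 nM

Both numbers come from a functional assay on A549 cells (Homo sapiens) for cytotoxicity, read by MTT assay, with a stated time of 24 h; on this read-out lower numbers stand for stronger inhibition and higher numbers for weaker inhibition. For compound 1 the result > 100000 nM is a limit of the assay, not a measured number. For compound 2 the result > 100000 nM is likewise only a limit. So compound 2 stands at the limit of > 100000 nM in this assay, at which 2 of the 2 values shown sit, with no finer number to place it. The next compound, compound 3 `C=CC1=C(C(=O)Nc2cccc(C)c2)C(c2ccc(F)cc2)OC1`, keeps everything in compound 2 except one group: 3-methylphenyl in place of 2-fluorobenzyl on an amide-type nitrogen. Going by the values given here, no pair of measured compounds differs in a single place, so no measured step shows what a swap on the amide nitrogen does in this assay. With compound 2 already at the limit, the expected step in this assay is none beyond the scatter, in either direction. The step expected is a step that the limit leaves unreadable from compound 2 to compound 3. Compound 3 is therefore estimated at about 150000 nM, in the range 40000 nM to 600000 nM, most likely reported only as a limit again.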

Compound 3, half-maximal inhibitory concentration: > 100000 nM
Compound 3: no number, only a limit; the forecaster's own chance of this, stated with the estimate: 75%; the middle value lies beyond the limit too.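

Going by these compounds alone, no step from compound 2 to compound 3 can be read, because both results are limits and not numbers: the limit of > 100000 nM in this assay, at which 3 of the 3 values shown sit. The compounds shown leave open whether any group on the amide nitrogen gives a measurable value in this assay, and how such groups would rank.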